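Replacing a Phenylethylamine Substituent with a Chloroaniline

This account rests on a few compounds, and the source may have more. Where it says the series, first, only, none or still open, it means among the compounds named here.

Of the compounds shown here, two sharing one core have been tested in a functional assay on PC-3 cells (Homo sapiens) for inhibition, read by MTT assay, with a stated time of 72 h; on this read-out lower numbers stand for stronger inhibition and higher numbers for weaker inhibition. Compound 1 `COc1cc2c(Nc3ccccc3[N+](=O)[O-])ncnc2c(OC)c1OC` gives 31200 nM. For the measured compounds named here, compound 2 `COc1cc2c(N[C@@H](C)c3ccccc3)ncnc2c(OC)c1OC` gives 10000 nM in this assay, the lowest of the two numbers; the only comparison, with compound 1, lies beyond the usual scatter, so compound 2 shows the stronger inhibition of the pair. Compound 3 `COc1cc2c(Nc3cccc(Cl)c3)ncnc2c(OC)c1OC` has not yet been measured in this assay. It differs from compound 2 in one place: 3-chlorophenyl in place of 1-phenylethyl on a nitrogen on an aromatic ring. No step between measured compounds touches this position, so there is no directly comparable precedent among the numbers shown; compound 1 carries a different aromatic substituent on the same nitrogen and is weaker, but its substituent is not the one entering here. The expectation is a modest step towards stronger inhibition, a 1.7-fold lower number from compound 2 to compound 3 (0.22 log units; within the scatter), with wide uncertainty in either direction. Compound 3 is therefore estimated to give 6000 nM in this assay, within a range from 1500 nM to 25000 nM.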

Compound 3, half-maximal inhibitory concentration: 19000 nM
Compound 3: middle estimate off by 3.2-fold (0.50 log units), on the low side; measured number inside the range.
By their numbers in this assay, from the lowest: compounds 2, 3 and 1 (each within the scatter of the next, the first and the last beyond it).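

In this assay, for the compounds shown here, the exchange of 1-phenylethyl for 3-chlorophenyl on the nitrogen gives a 1.9-fold higher number from compound 2 to compound 3 (0.28 log units; within the scatter) and is the first step that can be read at this position. It shows that the two groups are not told apart on this read-out, even though the exchange takes away the one defined stereocentre and brings in a chlorine on the aromatic ring, so at this level of resolution the position accepts either group. No measurement at hand bears on why the two groups read alike.

From the compounds shown here alone, how the opposite enantiomer of the 1-phenylethyl group would read stays open, as does the effect of a plain benzyl group or a longer chain, such as 2-phenylethyl, on the same nitrogen. Also open, going by these compounds, is whether a methoxy group or a nitrile in place of the chlorine on the aromatic ring would move the number beyond the usual scatter from that of compound 3.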